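The compounds below may be only part of what the source reports. "The series", "measured", "known", "first", "only" and "open" are said of these compounds alone.

Measured so far in an assay on HL-60 cells for agonist activity at vitamin D3 receptor (Homo sapiens), read by microscopy, with a stated time of 96 h; a lower number here means that less compound is needed, a higher number that more compound is needed for the effect:
- compound 1 `CCn1c(C(=O)NCCN(C)C)ccc1C(CC)(CC)c1ccc(OCC(=O)C(C)(C)C)c(C)c1`: 77 nM
- compound 2 `CCn1c(C(=O)NCCCN(C)C)ccc1C(CC)(CC)c1ccc(OCC(=O)C(C)(C)C)c(C)c1`: 96 nM
- compound 3 `CCn1c(C(=O)OC(C)CCO)ccc1C(CC)(CC)c1ccc(OCC(=O)C(C)(C)C)c(C)c1`: 380 nM

Compound 3 stands highest of the three numbers. The step of a 4.9-fold higher number from compound 1 to compound 3 (0.69 log units; beyond the scatter) and the step of a 4.0-fold higher number from compound 2 to compound 3 (0.60 log units; beyond the scatter) are both modest and beyond the scatter; each exchanges an amide-type nitrogen carrying a dimethylamino chain for the oxygen-containing group of compound 3. The step of a 1.2-fold higher number from compound 1 to compound 2 (0.10 log units; within the scatter) stays within the scatter.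

Compound 4 `CCn1c(C(=O)Nc2ccc(OC(F)(F)F)cc2)ccc1C(CC)(CC)c1ccc(OCC(=O)C(C)(C)C)c(C)c1` is not yet measured. Its change from compound 3: a group of 12 heavy atoms (7 carbon, 1 nitrogen, 1 oxygen, 3 fluorine; one six-membered aromatic ring of carbon only) in place of a group of 6 heavy atoms (4 carbon, 2 oxygen; no ring), on a carbonyl carbon. Among the compounds with values here, the carbonyl carbon thus again carries a nitrogen, as in compound 1 and compound 2, while the aromatic ring bearing trifluoromethoxy has no counterpart among the measured compounds. Because a 4.9-fold higher number from compound 1 to compound 3 (0.69 log units; beyond the scatter) and a 4.0-fold higher number from compound 2 to compound 3 (0.60 log units; beyond the scatter) were both modest upward steps, a modest downward step is expected on return to a nitrogen, widened for the untested aromatic part. Compound 4 is expected near 150 nM, range 40 nM to 600 nM, an expected step of a 2.5-fold lower number from compound 3 to compound 4 (0.40 log units; beyond the scatter).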

Compound 4, half-maximal effective concentration: > 50000 nM
Compound 4: only a limit was reported; the forecaster's own chance of this, stated with the estimate: 5%; middle value at least 330-fold (2.52 log units) from the limit.
By their numbers in this assay, from the lowest: compounds 1 and 2 (each within the scatter of the next); then compound 3. At a limit, above all of these: compound 4.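

In this assay, compound 4 gives only a limit of the assay, not a number: the limit of > 50000 nM in this assay, at which 1 of the 4 values shown sits.

A nitrogen on the carbonyl carbon does not by itself keep the numbers of compound 1 and compound 2: with 4-(trifluoromethoxy)phenyl on that nitrogen the changes are large, an at least 520-fold higher number from compound 2 to compound 4 (2.71 log units; beyond the scatter) and an at least 640-fold higher number from compound 1 to compound 4 (2.81 log units; beyond the scatter). The comparison with the oxygen-containing group is also large, an at least 130-fold higher number from compound 3 to compound 4 (2.11 log units; beyond the scatter), so among these four compounds, the group carried on the amide-type nitrogen counts for more than the choice of nitrogen or oxygen on the carbonyl carbon.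

The compounds shown do not separate the contribution of the aromatic ring from that of the trifluoromethoxy group. A plain phenyl, a 4-methoxyphenyl or a benzyl on the amide nitrogen would separate them, and a butyl chain would test the dimethylamino group.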